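Compound 3 to compound 4: a new chain end

The compounds below may be only part of what the source reports. "The series", "measured", "known", "first", "only" and "open" are said of these compounds alone.

In a physicochemical assay for solubility, in phosphate buffer, with a stated time of 18 h, at pH 7.4 (on this read-out higher numbers stand for higher solubility and lower numbers for lower solubility), compound 3 (`COc1cc2ncnc(-n3nc(-c4ccccn4)nc3N)c2cc1OCCNC(=O)OC(C)(C)C`) gives 2000 nM and sits in the middle of the three measured numbers. Compound 1 (`COc1cc2ncnc(-n3nc(-c4ccccn4)nc3N)c2cc1OCCCN1CC(C)OC(C)C1`) stands highest (8000 nM) and compound 2 (`COc1cc2ncnc(-n3nc(-c4ccccn4)nc3N)c2cc1OCCCCNC(=O)OC(C)(C)C`) stands lowest (500 nM).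

Compound 4 (`CCOC(=O)NCCCOc1cc2c(-n3nc(-c4ccccn4)nc3N)ncnc2cc1OC`) has not been measured yet. It carries ((ethoxycarbonyl)amino)methyl in place of (tert-butoxycarbonyl)amino on a saturated chain carbon, two bonds along the chain from an oxygen on an aromatic ring. Read one bond further out, 3-((ethoxycarbonyl)amino)propoxy replaces 2-((tert-butoxycarbonyl)amino)ethoxy.

The closest measured comparison puts (tert-butoxycarbonyl)amino in place of 2-((tert-butoxycarbonyl)amino)ethyl and shows a 4.0-fold higher number from compound 2 to compound 3 (0.60 log units; beyond the scatter) as a modest step. The modest 4.0-fold lower number from compound 1 to compound 3 (0.60 log units; beyond the scatter) and the large 16-fold lower number from compound 1 to compound 2 (1.20 log units; beyond the scatter) involve 2,6-dimethylmorpholin-4-yl and bear on this change less directly. Among the measured compounds shown here, no measured step shows ethoxycarbonyl replacing tert-butoxycarbonyl on its own, so the estimate stays wide.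

In this assay the expected outcome is no step beyond the scatter, with an estimated 1.3-fold lower number from compound 3 to compound 4 (0.12 log units; within the scatter) as the best guess. For compound 4 the estimated value is 1500 nM with an expected range from 500 nM to 5000 nM as the likely span.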

Compound 4, solubility: 16000 nM
Compound 4: middle estimate off by 11-fold (1.03 log units), on the low side, and the stated range ends below it.
By their numbers in this assay, from the lowest: compound 2; then compound 3; then compounds 1 and 4 (each within the scatter of the next).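

In this assay, the chain end at this position can give much higher numbers than the two tert-butoxycarbonyl compounds suggested: 3-((ethoxycarbonyl)amino)propoxy in place of 2-((tert-butoxycarbonyl)amino)ethoxy gives an 8.0-fold higher number from compound 3 to compound 4 (0.90 log units; beyond the scatter), and the comparison with the other tert-butoxycarbonyl chain gives a 32-fold higher number from compound 2 to compound 4 (1.51 log units; beyond the scatter). A chain end with 2,6-dimethylmorpholin-4-yl is also not required to reach this level, as the remaining comparison shows a 2.0-fold higher number from compound 1 to compound 4 (0.30 log units; within the scatter), which leaves no order between these two compounds. Nothing measured on these groups beyond this read-out accounts for the size of these steps.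

The step to compound 4 changes both the chain length and the group at its end, so the compounds shown cannot divide the rise between those two changes, and among the tert-butoxycarbonyl compounds it was the longer chain that gave the lower number. A 3-((tert-butoxycarbonyl)amino)propoxy or a 2-((ethoxycarbonyl)amino)ethoxy chain would separate the two changes, while a free primary amine at the chain end would show how much the ethoxycarbonyl group itself contributes.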